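A few compounds are considered here, and "the series" means these few. Any claim that something is new, unique, unknown or untested is made for them only; others in the source may bear on it.

Compound 1 `CN(C)CN1C(=O)C(=O)c2c(Br)cccc21` and compound 2 `O=C1C(=O)N(CN2CCCCC2)c2cccc(Br)c21` share one core; compound 3 `Cc1ccc2nc(/N=C3\C(=O)N(CN(C)C)c4cccc(Cl)c43)sc2c1` and compound 4 `Cc1ccc2nc(/N=C3\C(=O)N(CN4CCCCC4)c4cccc(Cl)c43)sc2c1` share another, and the difference between the two cores is not broken down here. In a functional assay on MCF7 cells (Homo sapiens) for cytotoxicity, read by sulforhodamine B assay, with a stated time of 48 h (on this read-out higher numbers stand for weaker inhibition of growth and lower numbers for stronger inhibition of growth), compound 1 gives 57600 nM, compound 2 gives 31500 nM and compound 3 gives 20700 nM. The change from compound 1 to compound 2, (piperidin-1-yl in place of dimethylamino on a saturated chain carbon bound to an amide-type nitrogen in a ring), made a 1.8-fold lower number from compound 1 to compound 2 (0.26 log units; within the scatter). The same change, (piperidin-1-yl in place of dimethylamino on a saturated chain carbon bound to an amide-type nitrogen in a ring), leads from compound 3 to compound 4. Among the measured compounds shown here, with only one earlier instance, and that one within the scatter, the step to compound 4 is expected to be of about that size, so a 1.5-fold lower number from compound 3 to compound 4 (0.17 log units; within the scatter) is estimated in this assay. For compound 4 the expected value in this assay is 14000 nM, with a likely range from 6000 nM to 35000 nM.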

Compound 4, concentration for 50% growth inhibition: 30900 nM
Estimate against measurement, compound 4: 2.2-fold (0.34 log units) below; the measured number falls inside the stated range.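

In this assay the exchange of dimethylamino for piperidin-1-yl gives a 1.5-fold higher number from compound 3 to compound 4 (0.17 log units; within the scatter). Set beside the earlier step, the exchange does not carry over as one fixed shift from one core to the other: the same change on two cores in this assay, a 1.8-fold lower number (0.26 log units; within the scatter) from compound 1 to compound 2 and a 1.5-fold higher number (0.17 log units; within the scatter) from compound 3 to compound 4, 2.7-fold (0.44 log units) apart, beyond the scatter of two such steps Each step taken alone lies within the scatter, so neither pair shows a firm effect of the exchange on its own core, and two pairs give no rule for any other core.

As far as these compounds go, whether morpholin-4-yl or 4-methylpiperazin-1-yl in the same place would follow either step remains open. Also open, from the compounds shown here alone, is which of the differences between the two cores goes with the gap between the steps.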